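Swapping the Pyridylmethylamine Side Chain on a Shared Core

The source may report more compounds than this note shows. Statements on the series, on what has been measured and on what is new or still open speak of the compounds shown alone.

Measured so far:
- Compound 1, `c1ccc2c(c1)CN[C@@H](CN(CCCCNCc1ccncc1)[C@H]1CCCc3cccnc31)C2`: in a functional assay on cells for agonist activity at C-X-C chemokine receptor type 4 (Homo sapiens), read by fluorescence and calcium flux, with a stated time of 90 s (on this read-out higher numbers stand for an effect only at larger amounts of compound and lower numbers for an effect already at smaller amounts), compound 1 gives > 30000 nM, which is a limit of the assay, not a number.
- Compound 2, `FC1(F)CCC(NC/C=C/CN(C[C@H]2Cc3ccccc3CN2)[C@H]2CCCc3cccnc32)CC1`: in this assay compound 2 gives > 30000 nM, again a limit of the assay.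

Both values therefore tell only that no effect was seen up to the highest amount tested. Going by the values given here, compound 1 stands at that limit, and so does the one other value shown; this is summed up in the line (the limit of > 30000 nM in this assay, at which 2 of the 2 values shown sit). Nothing here separates the two compounds from each other.

Compound 3, `C(=C/CN(C[C@H]1Cc2ccccc2CN1)[C@H]1CCCc2cccnc21)\CNCc1cccnc1`, has not yet been tested. Compared with compound 1 the change is a group of 11 heavy atoms (9 carbon, 2 nitrogen; one six-membered aromatic ring with 1 hetero atom) in place of a group of 11 heavy atoms (9 carbon, 2 nitrogen; one six-membered aromatic ring with 1 hetero atom), on a saturated chain carbon bound to an amine nitrogen. The side arm keeps its size and its count of donors and acceptors, and only the chain and the position of the ring nitrogen shift.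

Among the compounds with values here, with both measured compounds sitting at the limit, there is no measured step to lean on. The expected step in this assay is a number no higher from compound 1 to compound 3 (the limit leaves the size open), which is none beyond the scatter. Compound 3 is expected to give 30000 nM, most likely again as a limit, with a range from 10000 nM to 100000 nM.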

Compound 3, half-maximal effective concentration: > 30000 nM
Compound 3 was reported as a limit (the forecaster's own chance of this, stated with the estimate: 75%); the middle value sits exactly at the limit.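

Compound 3 sits at the same limit as compound 1 and compound 2, so the steps from compound 1 and compound 2 to compound 3 cannot be read: the limit of > 30000 nM in this assay, at which 3 of the 3 values shown sit.

The compounds shown leave open whether any side arm on the shared core gives a measurable effect in this assay and how these side arms would rank against one another.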